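Hydroxy-to-hydrogen swaps in a series of aryloxypropyl piperidines

This account rests on a few compounds, and the source may have more. Where it says the series, first, only, none or still open, it means among the compounds named here.

Compound 1 `COc1cc(C(C)=O)ccc1OCCCN1CCC(C(c2ccc(F)c(F)c2)c2ccc(F)c(F)c2)CC1` and compound 2 `COc1cc(C(C)=O)ccc1OCCCN1CCC(C(O)(c2ccc(F)c(F)c2)c2ccc(F)c(F)c2)CC1` share one core and differ only at one carbon. In a functional assay (aorta) with Oryctolagus cuniculus as the target (on this read-out lower numbers stand for tighter binding and higher numbers for weaker binding), compound 1 gives 2.51 nM and compound 2 gives 2.51 nM, so the step of no change at the digits printed from compound 2 to compound 1 (within the scatter) is hydrogen in place of hydroxy on a saturated chain carbon bound to two aromatic carbons and a saturated ring carbon. Compound 3 `COc1cc(C(C)O)ccc1OCCCN1CCC(C(c2ccc(F)cc2)c2ccc(F)cc2)CC1` rests on another core; the difference between the two cores is not broken down here. In this assay compound 3 gives 10 nM. Compound 4 `CCc1ccc(OCCCN2CCC(C(c3ccc(F)cc3)c3ccc(F)cc3)CC2)c(OC)c1` is obtained from compound 3 by the same kind of change, (hydrogen in place of hydroxy on a saturated chain carbon bound to an aromatic carbon and a saturated chain carbon), though here the carbon is bound to an aromatic carbon and a saturated chain carbon rather than to two aromatic carbons and a saturated ring carbon. Because no change at the digits printed from compound 2 to compound 1 (within the scatter) shows no change, the step from compound 3 to compound 4 is expected to be small, a 1.3-fold lower number from compound 3 to compound 4 (0.10 log units; within the scatter). Compound 4 is estimated at 8 nM, between 3 nM and 25 nM.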

Compound 4, dissociation constant: 2.51 nM
The estimate for compound 4 lay 3.2-fold (0.50 log units) above the measured number, outside the stated range (below it).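

In this assay, replacing hydroxy with hydrogen did not have the same effect on the two cores: the same change on two cores in this assay, no change at the digits printed (within the scatter) from compound 2 to compound 1 and a 4.0-fold lower number (0.60 log units; beyond the scatter) from compound 3 to compound 4, 4.0-fold (0.60 log units) apart, beyond the scatter of two such steps On the core of compound 3, the change from 1-hydroxyethyl to ethyl gives a 4.0-fold lower number from compound 3 to compound 4 (0.60 log units; beyond the scatter), so a null result on the core of compound 1 did not carry over to this core. These two pairs do not show whether the gap comes from the cores themselves or from the different carbon bearing the hydroxy in each pair.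

As far as these compounds go, it remains open how the same swap would behave at one carbon on both cores. From the compounds shown here alone, it is also open what an amine or a carboxylic acid would do in place of the hydroxy on the 1-hydroxyethyl group.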